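A few compounds are considered here, and "the series" means these few. Any claim that something is new, unique, unknown or untested is made for them only; others in the source may bear on it.

Measured compounds:
Compound 1, `CCCCCc1ccc(-c2cc3cn([C@H]4C[C@H](O)[C@@H](CO)O4)c(=O)nc3o2)nc1`, in an ADME assay on HEL cells (Homo sapiens) for cytotoxicity, with a stated time of 3 days (on this read-out lower numbers stand for higher toxicity in this test and higher numbers for lower toxicity in this test), compound 1 gives > 100000 nM, which is a limit of the assay rather than a number.
Compound 2, `CCCCCc1cnc(-c2cc3cn([C@H]4C[C@H](O)[C@@H](CO)O4)c(=O)nc3o2)nc1`, in this assay compound 2 gives > 100000 nM, again a limit of the assay.
Compound 3, `CCCCc1ccc(-c2cc3cn([C@H]4C[C@H](O)[C@@H](CO)O4)c(=O)nc3o2)nc1`, in this assay compound 3 gives > 100000 nM, also a limit of the assay.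

The three measured compounds share a sugar-bearing bicyclic portion and differ in the pendant ring and its chain. Compound 1 differs from compound 3 by methyl in place of hydrogen on a saturated chain carbon, four bonds along the chain from an aromatic carbon. That change produced a step that the two limits leave unreadable from compound 3 to compound 1, which reflects (the limit of > 100000 nM in this assay, at which 3 of the 3 values shown sit). How the core of compound 2 differs from the core of compound 3 is not broken down here; what the two values show is that both sit at the same limit of the assay.

Compound 4, `CCCCCCc1cnc(-c2cc3cn([C@H]4C[C@H](O)[C@@H](CO)O4)c(=O)nc3o2)nc1`, has not yet been measured in this assay. It differs from compound 2 by methyl in place of hydrogen on a saturated chain carbon, five bonds along the chain from an aromatic carbon. Among the compounds with values here, this is the same kind of change as the one from compound 3 to compound 1, but not the same: in the earlier pair the new methyl sits four bonds along the chain from an aromatic carbon, whereas here it sits five bonds along the chain from an aromatic carbon.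

For compound 4 the expected step is a number no higher from compound 2 to compound 4 (the limit leaves the size open), and this expectation rests on compound 2 giving > 100000 nM together with the unreadable step that the two limits leave unreadable from compound 3 to compound 1 for the same kind of change. Compound 4 is therefore estimated at 100000 nM, with the expected range running from 50000 nM to 300000 nM, and most likely the assay will again report only a limit.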

Compound 4, minimum cytotoxic concentration: > 100000 nM
Compound 4 ended at the assay's limit (the forecaster's own chance of this, stated with the estimate: 85%); the middle value sits exactly at the limit.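

In this assay compound 4 ends at a limit of the assay, as compound 2 does, so no step can be read between compound 2 and compound 4: the limit of > 100000 nM in this assay, at which 4 of the 4 values shown sit.

The compounds shown leave open whether a longer chain or a different pendant ring changes the minimum cytotoxic concentration at all; none of the four gives a number.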